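Swapping a difluorophenyl for an octyl chain on an alkyne

The source may report more compounds than this note shows. Statements on the series, on what has been measured and on what is new or still open speak of the compounds shown alone.

Measured compounds:
compound 1 `CC(=O)OCC(CCn1cc(C#CC2CC2)c(=O)n(C(=O)c2ccccc2)c1=O)COC(C)=O`: > 100000 nM (a limit)
compound 2 `O=c1[nH]c(=O)n(CCC(CO)CO)cc1C#Cc1cc(F)cc(F)c1`: 31200 nM

Within the data shown here, in a functional assay on HeLa cells (Homo sapiens) for antiproliferative activity, read by MTT assay, with a stated time of 72 h (a lower number here means a stronger inhibitor, a higher number a weaker inhibitor), compound 2 gives 31200 nM, the only number among the two values shown. Compound 1 reaches only a limit, > 100000 nM, in this assay, as noted in the limit of > 100000 nM in this assay, at which 1 of the 2 values shown sits. Compound 3 `CCCCCCCCC#Cc1cn(CCC(CO)CO)c(=O)[nH]c1=O` is not yet measured; it differs from compound 2 by octyl in place of 3,5-difluorophenyl on a triple-bonded carbon. Among the measured compounds shown here, no measured pair shows a step of this kind, so the direction is open; a modest loss or no change beyond the scatter seems likeliest. For compound 3 the expected value in this assay is 30000 nM, between 7000 nM and 100000 nM, which means an expected step of a 1.0-fold lower number from compound 2 to compound 3 (0.02 log units; within the scatter).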

Compound 3, half-maximal inhibitory concentration: 58900 nM
The estimate for compound 3 lay 2.0-fold (0.29 log units) below the measured number, and the stated range covers the measured number.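

Putting octyl in place of 3,5-difluorophenyl on the triple-bonded carbon gives a 1.9-fold higher number from compound 2 to compound 3 (0.28 log units; within the scatter) in this assay. Among these compounds, this is the first comparison of compounds that differ in one place, and it shows that an aromatic ring at this position is not required to keep the weak activity seen with compound 2. Nothing shown here explains this result.

On these data alone, it remains open whether a shorter chain, or a chain ending in an amine or a carboxylic acid, would give a clearly different number. The compounds shown also cannot tell whether any group at this position gives strong activity.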